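This account rests on a few compounds, and the source may have more. Where it says the series, first, only, none or still open, it means among the compounds named here.

Measured so far:
compound 1, `COc1ccccc1-c1csc2cnc(Nc3ccc(C(=O)NC4CCNCC4)cc3C)nc12`, 3240 nM;
compound 2, `COc1ccccc1-c1csc2cnc(Nc3ccc(C(=O)NC4CCNCC4)cc3C(F)(F)F)nc12`, 2750 nM;
compound 3, `CNC(=O)c1ccc(Nc2ncc3scc(-c4ccccc4OC)c3n2)cc1`, 2120 nM.

In a functional assay on MDA-MB-231 cells (Homo sapiens) for inhibition, read by MTT assay, with a stated time of 72 h (a lower number here means a stronger inhibitor, a higher number a weaker inhibitor), compound 1 gives the highest of the three numbers, yet it is separated from compound 2 by a 1.2-fold lower number from compound 1 to compound 2 (0.07 log units; within the scatter) and its gap to compound 3 is likewise within the scatter, so the three compounds are not told apart here. Compound 4, `COc1ccccc1-c1csc2cnc(Nc3ccc(C(=O)NC4CCNCC4)cc3)nc12`, differs from compound 1 in one place: hydrogen in place of methyl on an aromatic carbon. For the measured compounds named here, the one measured step that bears on this position is the exchange from compound 1 to compound 2, trifluoromethyl in place of methyl, which moved the number by a 1.2-fold lower number from compound 1 to compound 2 (0.07 log units; within the scatter). Going by the values given here, compound 3 carries hydrogen at this position but also a different amide, so no single-point step to it is available; its value of 2120 nM simply sits near the others. Removing the methyl is therefore expected to leave this assay essentially unchanged, with a 1.2-fold lower number from compound 1 to compound 4 (0.10 log units; within the scatter) as the expected step. Compound 4 is estimated at 2600 nM, within a range of 1200 nM to 5600 nM.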

Compound 4, half-maximal inhibitory concentration: 110 nM
Beside the measured number, compound 4's estimate is 24-fold (1.37 log units) above it, and the stated range ends above it.
By their numbers in this assay, from the lowest: compound 4; then compounds 3, 2 and 1 (each within the scatter of the next).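

In this assay, for the compounds shown here, this position, ortho to a large group, proves far more sensitive than the earlier compounds suggested: the exchange between methyl and trifluoromethyl gave only a 1.2-fold lower number from compound 1 to compound 2 (0.07 log units; within the scatter) and so hid what hydrogen does here. Hydrogen in place of either group gives a 29-fold lower number from compound 1 to compound 4 (1.47 log units; beyond the scatter) and also a 25-fold lower number from compound 2 to compound 4 (1.40 log units; beyond the scatter) so both substituted compounds stand well apart from compound 4. Going by these compounds alone, with hydrogen on this ring the amide also counts, since piperidin-4-yl in place of methyl on the amide-type nitrogen gives a 19-fold lower number from compound 3 to compound 4 (1.28 log units; beyond the scatter) and this is the first readable step at that nitrogen. Nothing given here accounts for the size of these steps.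

The compounds shown leave open whether only hydrogen is favoured at this position or whether a fluorine atom, a chlorine atom or an amine would also keep the low number. They also leave open whether a longer chain on the amide nitrogen would do as well as piperidin-4-yl.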